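The source may report more compounds than this note shows. Statements on the series, on what has been measured and on what is new or still open speak of the compounds shown alone.

Measured compounds:
Compound 1, `O=S(=O)(Nc1ccc2oc(-c3ccccc3)nc2c1)c1ccccc1C(F)(F)F`: in an assay on cells for inhibition of HSP60/HSP10 (Homo sapiens), with a stated time of 60 min (on this read-out higher numbers stand for weaker inhibition and lower numbers for stronger inhibition), compound 1 gives > 100000 nM, which is a limit of the assay and not a number.
Compound 2, `O=S(=O)(Nc1ccc2oc(-c3ccccc3)nc2c1)c1ccccc1Cl`: compound 2 gives > 100000 nM, again a limit.
Compound 3, `O=S(=O)(Nc1ccc2oc(-c3ccccc3)nc2c1)c1ccc(Cl)c(C(F)(F)F)c1`: compound 3 gives > 100000 nM, again a limit.

Compound 2 therefore stands only at a limit, and both other values shown are limits as well (the limit of > 100000 nM in this assay, at which 3 of the 3 values shown sit). Among the measured compounds shown here, the one step between measured compounds that differ in a single place, a step that the two limits leave unreadable from compound 1 to compound 2, cannot be read because both of its ends are limits. The unmeasured compound 4, `C=Cc1ccc(S(=O)(=O)Nc2ccc3oc(-c4ccccc4)nc3c2)cc1`, differs from compound 2 by a single change: 4-vinylphenyl in place of 2-chlorophenyl on a sulfonyl sulfur. For the measured compounds named here, no measured step bears on this change, so there is no ground for expecting a move beyond the scatter in either direction in this assay. The expected step of a number no higher from compound 2 to compound 4 (the limit leaves the size open) is therefore put near zero, with most of the chance that compound 4 also stops at the limit. The estimate for compound 4 is 100000 nM, within a range from 30000 nM to 300000 nM.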

Compound 4, half-maximal inhibitory concentration: > 100000 nM
Compound 4 gave a limit, no number; the forecaster's own chance of this, stated with the estimate: 80%; the middle value lies on the limit itself.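

Compound 4 gives > 100000 nM, which is a limit of the assay and not a number, and compound 2 also stands at a limit, so the step between them cannot be read. The compounds shown leave open what change, if any, would give a measurable value in this assay: the limit of > 100000 nM in this assay, at which 4 of the 4 values shown sit.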